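Chloro for fluoro on the pendant phenyl ring

The source may report more compounds than this note shows. Statements on the series, on what has been measured and on what is new or still open speak of the compounds shown alone.

Four oxime ethers are compared. Compound 1 `CCc1nn(C)c(CO/N=C/c2c(C)nn(C)c2Oc2ccc(F)cc2)c1Cl` and compound 3 `CCc1nn(C)c(CO/N=C/c2c(C)nn(C)c2Oc2ccc(Cl)cc2)c1Cl` share one core; compound 2 `Cc1nn(C)c(Oc2ccc(F)cc2)c1/C=N\OCc1c(Cl)c(-c2ccc(F)cc2)nn1C` and the yet unmeasured compound 4 `Cc1nn(C)c(Oc2ccc(F)cc2)c1/C=N\OCc1c(Cl)c(-c2ccc(Cl)cc2)nn1C` share another. The difference between the two cores is not broken down here.

In a functional assay on SMMC-7721 cells (Homo sapiens) for inhibition, read by MTT assay, with a stated time of 72 h, tested at 25 uM (on this read-out higher numbers stand for more inhibition at the one concentration tested (going by the name of the read-out) and lower numbers for less inhibition), compound 1 gives < 80%, which is a limit of the assay and not a number. In this assay compound 3 likewise gives < 80%, again a limit. The change between them is chloro in place of fluoro on an aromatic carbon, and its size is a step that the two limits leave unreadable from compound 1 to compound 3. For the measured compounds named here, compound 2 gives 80% in this assay, the only number among the three values shown.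

Compound 4 carries the same change, (chloro in place of fluoro on an aromatic carbon), on the second core. What that change did on the first core cannot be read, because of the limit of < 80% in this assay, at which 2 of the 3 values shown sit. With compound 2 at 80% as the starting point and no readable precedent, a small step of a number 6 percentage points lower from compound 2 to compound 4 (within the scatter) is expected. Compound 4 is therefore estimated at 74%, between 55% and 90%.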

Compound 4, a percentage reported as inhibition, at one concentration (the size of the read-out at that concentration, not a potency): 80%
Compound 4: the middle estimate sits 6 percentage points below what was measured, and the stated range covers the measured number.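

On the core of compound 2, 4-fluorophenyl to 4-chlorophenyl gives, in this assay, no change at the digits printed from compound 2 to compound 4 (within the scatter), so on this core the read-out does not separate chloro from fluoro on the aromatic carbon at the one concentration tested, and this says nothing about potency. The same change on the core of compound 1 gives no readable step, and the pair from compound 1 to compound 3 offers only limits of the assay rather than numbers. The result therefore shows how the change reads on one core only and does not show that it carries from one core to the other, because the comparison on the first core is closed off: the limit of < 80% in this assay, at which 2 of the 4 values shown sit.

The compounds shown hold only fluoro and chloro at this place on the phenyl ring. They leave open what a bromo, a methoxy, a dimethylamino group or a carboxylic acid there would give in this assay, on either core.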